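Nitro in place of hydrogen on the ring of compound 1

The source may hold more compounds than are shown below. What is called first, only, known or untested is meant among the compounds shown, and "the series" means these compounds.

Measured so far in a functional assay on L1210 cells (Mus musculus) for antiproliferative activity; on this read-out higher numbers stand for weaker inhibition and lower numbers for stronger inhibition:
compound 1 `C=C1C(=O)ON(C)C1c1ccccc1`: 5500 nM
compound 2 `C=C1C(=O)ON(C)C1c1ccc(OC)cc1`: 3500 nM

Compound 1 stands highest of the two numbers in this assay, with compound 2 nearest to it. Compound 3 `C=C1C(=O)ON(C)C1c1ccc([N+](=O)[O-])cc1` differs from compound 1 by nitro in place of hydrogen on an aromatic carbon. Among the compounds with values here, the only measured change at this place is a different group, and it gave a 1.6-fold lower number from compound 1 to compound 2 (0.20 log units; within the scatter), a step within the scatter. On that basis no step beyond the scatter is expected for the nitro group either, in either direction. Compound 3 is therefore estimated at 5000 nM, between 1500 nM and 16000 nM. That estimate means an expected step of a 1.1-fold lower number from compound 1 to compound 3 (0.04 log units; within the scatter).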

Compound 3, half-maximal inhibitory concentration: 800 nM
Estimate against measurement, compound 3: 6.3-fold (0.80 log units) above, and the stated range ends above it.
By their numbers in this assay, from the lowest: compound 3; then compounds 2 and 1 (each within the scatter of the next).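

In this assay this position can move the number beyond the scatter: nitro in place of hydrogen gives a 6.9-fold lower number from compound 1 to compound 3 (0.84 log units; beyond the scatter) while the earlier methoxy step stayed within it. Nitro in place of methoxy gives a 4.4-fold lower number from compound 2 to compound 3 (0.64 log units; beyond the scatter) as well, so the two groups are told apart at this place and compound 3 stands lowest of the three. No evidence at hand bears on this result. Going by these compounds, it remains open whether an amine or a carboxylic acid at this place would give a step of similar size. On these data alone, it also remains open whether nitro would do the same on another aromatic carbon of the ring.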